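Weak Inhibitors and a Larger Ether Group

This account rests on a few compounds, and the source may have more. Where it says the series, first, only, none or still open, it means among the compounds named here.

Compound 1 `O=C1OC(Cc2nc(Cc3ccccc3)no2)c2ccccc21` and compound 2 `CCC(C)Oc1ccc(C(O)C2OC(=O)c3c(OC)cc(OC)cc32)cc1` were both tested in a functional assay on RAW264.7 cells (Mus musculus) for inhibition, read by Griess assay, with stated times of 1 h and 24 h; a higher number here means a weaker inhibitor, a lower number a stronger inhibitor. In this assay compound 1 gives > 10000 nM, which is a limit of the assay rather than a number. Compound 2 gives > 10000 nM in this assay, again a limit and not a measured number. Compound 2 thus sits at the limit of > 10000 nM in this assay, at which 2 of the 2 values shown sit, so no definite inhibition has been pinned down for it. Compound 3 `COc1cc(OC)c2c(c1)C(C(O)c1ccc(OCc3ccc(Cl)cc3)cc1)OC2=O` is not yet measured. It differs from compound 2 in one place: 4-chlorobenzyl in place of sec-butyl on an oxygen on an aromatic ring. With both shown values at a limit, there is no measured step to lean on, and nothing in the numbers says which way this change will move the result. The step of a number no higher from compound 2 to compound 3 (the limit leaves the size open) is expected to be none beyond the usual scatter. Compound 3 is expected to give 10000 nM, within a range from 2500 nM to 40000 nM in this assay.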

Compound 3, half-maximal inhibitory concentration: 4320 nM
Compound 3: middle estimate off by 2.3-fold (0.36 log units), on the high side, and the stated range covers the measured number.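

This position on the shared core responds to change: 4-chlorobenzyl in place of sec-butyl on the oxygen gives an at least 2.3-fold lower number from compound 2 to compound 3 (0.36 log units; beyond the scatter) in this assay. Compound 3 is therefore the only compound shown with a definite number, and a lower number here means a stronger inhibitor. The true size of the step remains unknown, and it could be larger, because compound 2 gives only a limit and not a number: the limit of > 10000 nM in this assay, at which 2 of the 3 values shown sit.

This single step cannot separate the contribution of the added ring from that of the chlorine, and a plain benzyl on the same oxygen would tell them apart. On these data alone, whether a different kind of group here, such as a chain ending in an amine, would keep or lose this inhibition also remains open.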